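A few compounds are considered here, and "the series" means these few. Any claim that something is new, unique, unknown or untested is made for them only; others in the source may bear on it.

Measured so far:
compound 1, `C=CCc1cc(C(C)=O)c(O)cc1OCCCCC#N`, 57%
compound 2, `C=CCc1cc(C(C)=O)c(O)cc1OCCCCCCCCC#N`, 50%
compound 3, `C=CCc1cc(C(C)=O)c(O)cc1OCCCCC`, 23%

All three were tested in an assay on isolated protein for binding affinity to leukotriene B4 receptor 1 (Homo sapiens), tested at 1 uM; on this read-out higher numbers stand for more inhibition at the one concentration tested (going by the name of the read-out) and lower numbers for less inhibition. Compound 3 gives the lowest of the three numbers: its nearest neighbour is compound 2, and that gap, a number 27 percentage points lower from compound 2 to compound 3 (beyond the scatter), lies beyond the scatter, as does the larger gap to compound 1, a number 34 percentage points lower from compound 1 to compound 3 (beyond the scatter). Compound 4, `C=CCc1cc(C(C)=O)c(O)cc1OCCCCCCC`, has not yet been measured. It differs from compound 3 at a single place: ethyl in place of hydrogen on a saturated chain carbon, five bonds along the chain from an oxygen on an aromatic ring. Within the data shown here, only one measured step changes the length of the chain without touching anything else, the one from compound 1 to compound 2, a number 7 percentage points lower from compound 1 to compound 2 (within the scatter), which stayed inside the scatter. The two large steps both remove the nitrile, and no nitrile is involved in the change from compound 3 to compound 4. On this basis no step beyond the scatter is expected in this assay, so compound 4 is estimated at 25%, with a range from 10% to 45%. The expected step is therefore a number 2 percentage points higher from compound 3 to compound 4 (within the scatter), within the usual scatter.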

Compound 4, a percentage reported as inhibition, at one concentration (the size of the read-out at that concentration, not a potency): 8%
Compound 4: the middle estimate sits 17 percentage points above what was measured; measured number outside the range, below it.
By their numbers in this assay, from the lowest: compound 4; then compound 3; then compounds 2 and 1 (each within the scatter of the next).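

In this assay, chain length alone does matter once no nitrile ends the chain: ethyl in place of hydrogen on this saturated chain carbon, five bonds along the chain from an oxygen on an aromatic ring, gives a number 15 percentage points lower from compound 3 to compound 4 (beyond the scatter). The two nitrile-ending chains, by contrast, stayed within the scatter of each other despite their difference in length. The nitrile compounds also stand further from this longer plain chain, with a number 42 percentage points lower from compound 2 to compound 4 (beyond the scatter) and a number 49 percentage points lower from compound 1 to compound 4 (beyond the scatter); no measurement shown here explains why the number falls as the plain chain grows.

From the compounds shown here alone, it remains open whether a longer chain would lower the number further. Also open, going by these compounds, is whether an amine or a carboxylic acid at the chain end could take the place of the nitrile.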